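Methoxy Placement on the Hydroxamic Acid Arm

The source may hold more compounds than are shown below. What is called first, only, known or untested is meant among the compounds shown, and "the series" means these compounds.

Compound 1 `Cc1cc2cc(NS(=O)(=O)Cc3cccc(C(=O)NO)c3)ccc2n(C)c1=O` gives 0% in a functional assay on HL-60 cells (Homo sapiens) for antiproliferative activity, tested at 100 uM; on this read-out lower numbers stand for a weaker effect and higher numbers for a stronger effect at the one concentration tested. Compound 2 `COc1cc(C(=O)NO)ccc1CS(=O)(=O)Nc1ccc2c(c1)cc(C)c(=O)n2C`, which also carries a methoxy, gives 0%, level with compound 1 at the digits shown, and the two together stand lowest of the three numbers. Compound 3 `COC(=O)c1ccc(CS(=O)(=O)Nc2ccc3c(c2)cc(C)c(=O)n3C)cc1`, the methyl ester, gives 78%, well beyond the scatter above compound 1. Compound 4 `COc1ccc(C(=O)NO)cc1CS(=O)(=O)Nc1ccc2c(c1)cc(C)c(=O)n2C` remains unmeasured. Its difference from compound 1: methoxy in place of hydrogen on an aromatic carbon. For the measured compounds named here, no measured pair shows this change directly. Since compound 2 gives 0% with its own methoxy, no step beyond the scatter is expected here. The expected step from compound 1 to compound 4 is a number 5 percentage points higher from compound 1 to compound 4 (within the scatter). Compound 4 is estimated at 5%, within 0% to 30%.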

Compound 4, a percentage reported as inhibition, at one concentration (the size of the read-out at that concentration, not a potency): 0%
Compound 4: the middle estimate sits 5 percentage points above what was measured; the measured number falls inside the stated range.
By their numbers in this assay, from the lowest: compounds 1, 2 and 4 (each within the scatter of the next); then compound 3.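

In this assay, for the compounds shown here, the step is no change at the digits printed from compound 1 to compound 4 (within the scatter) for methoxy in place of hydrogen on an aromatic carbon, para to a hydroxycarbamoyl group and ortho to a large group, the first direct reading of this change at this position. Compound 1 starts from 0% on this read-out, so the pair shows no gain from the methoxy at the one concentration tested but cannot reveal a loss. Still open, from the compounds shown here alone, is whether an amine, a fluorine or a longer alkoxy chain at this position would lift the read-out above that of compound 1. Nothing measured here explains the flat step.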